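Chloro in place of methoxy: the next step from compound 3

The source may hold more compounds than are shown below. What is called first, only, known or untested is meant among the compounds shown, and "the series" means these compounds.

Three compounds share one core. Compound 1 `O=C(NC(=S)Nc1ccc(F)cc1)c1cn(-c2ccccc2)nc1-c1ccccc1` gives 4210 nM in a functional assay on NCI-H460 cells (Homo sapiens) for inhibition, read by CCK-8 assay, with a stated time of 48 h; on this read-out lower numbers stand for stronger inhibition and higher numbers for weaker inhibition. Compound 2 `O=C(NC(=S)Nc1ccc(Cl)cc1)c1cn(-c2ccccc2)nc1-c1ccc(Cl)cc1` gives 3260 nM in this assay. Compound 3 `COc1ccc(-c2nn(-c3ccccc3)cc2C(=O)NC(=S)Nc2ccc(F)cc2)cc1` gives 3050 nM in this assay, and all three numbers lie within the scatter of one another, so compound 3 is not set apart from the others. For the measured compounds named here, the one step among them, a 1.4-fold lower number from compound 1 to compound 3 (0.14 log units; within the scatter), stayed within the scatter. Compound 4 `O=C(NC(=S)Nc1ccc(F)cc1)c1cn(-c2ccccc2)nc1-c1ccc(Cl)cc1` shows (chloro in place of methoxy on an aromatic carbon). Compound 2 also carries chloro at that place, and its number against compound 3 shows nothing beyond the scatter. Going by the values given here, with no step pointing beyond the scatter, compound 4 is expected to give about 3400 nM, between 1700 nM and 6800 nM. That estimate means a step of a 1.1-fold higher number from compound 3 to compound 4 (0.05 log units; within the scatter), expected to stay within the scatter.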

Compound 4, half-maximal inhibitory concentration: 3640 nM
For compound 4 the middle estimate is 1.1-fold (0.03 log units) below the measured one; the range from low to high includes it.
By their numbers in this assay, from the lowest: compounds 3, 2, 4 and 1 (each within the scatter of the next).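

In this assay, hydrogen, methoxy and chloro at this place on the aromatic ring cannot be told apart: chloro in place of methoxy gives (a 1.2-fold higher number from compound 3 to compound 4 (0.08 log units; within the scatter)) and chloro in place of hydrogen gives (a 1.2-fold lower number from compound 1 to compound 4 (0.06 log units; within the scatter)). Fluoro in place of chloro at a second aromatic carbon also stays within the scatter (a 1.1-fold higher number from compound 2 to compound 4 (0.05 log units; within the scatter)). No evidence bearing on these results is available.

From the compounds shown here alone, whether an amine or a carboxylic acid on that aromatic carbon would give a step beyond the scatter remains open.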